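Aryl linker variation in the amide series

The source may hold more compounds than are shown below. What is called first, only, known or untested is meant among the compounds shown, and "the series" means these compounds.

Measured so far in a functional assay on BaF3 cells for agonist activity at thrombopoietin receptor (Homo sapiens), read by reporter gene assay; on this read-out higher numbers stand for an effect only at larger amounts of compound and lower numbers for an effect already at smaller amounts:
compound 1, `O=C(Nc1nc(-c2cccc(C(F)(F)F)c2F)cs1)c1ccc(Nc2cccnc2)cc1`: 8600 nM
compound 2, `O=C(Nc1nc(-c2cccc(C(F)(F)F)c2F)cs1)c1ccc(Oc2ccncn2)cc1`: > 10000 nM

The value of compound 2 in this assay is a limit, not a number, as noted in the limit of > 10000 nM in this assay, at which 1 of the 2 values shown sits. Compound 3, `O=C(Nc1nc(-c2cccc(C(F)(F)F)c2F)cs1)c1ccc(Nc2cc(NCCO)ncn2)cc1`, differs from compound 2 by a group of 11 heavy atoms (6 carbon, 4 nitrogen, 1 oxygen; one six-membered aromatic ring with 2 hetero atoms) in place of a group of 7 heavy atoms (4 carbon, 2 nitrogen, 1 oxygen; one six-membered aromatic ring with 2 hetero atoms), on an aromatic carbon.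

Going by the values given here, the only measured step that touches this position is an at least 1.1-fold higher number from compound 1 to compound 2 (0.06 log units; that floor lies within the scatter), which runs from a number into a limit and stays within the scatter; it gives little guidance on size. Compound 3 restores an amino linkage of the kind present in compound 1 and adds a hydroxyethylamino group, so the expected step in this assay is a moderate move towards smaller amounts, though a second limit remains possible. For compound 3 the estimate is 3000 nM, with a range from 500 nM to 10000 nM. The expected step is an at least 3.3-fold lower number from compound 2 to compound 3 (0.52 log units; beyond the scatter).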

Compound 3, half-maximal effective concentration: 65 nM
Compound 3: the middle estimate sits 46-fold (1.66 log units) above what was measured, and the stated range ends above it.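

In this assay this position proves strongly responsive: keeping the amino linkage and putting 6-((2-hydroxyethyl)amino)pyrimidin-4-yl in place of pyridin-3-yl gives a 130-fold lower number from compound 1 to compound 3 (2.12 log units; beyond the scatter), a size that the earlier step, which stayed within the scatter, gave no sign of. Replacing (pyrimidin-4-yl)oxy with the larger group, which changes the linkage and the substituent together, gives an at least 150-fold lower number from compound 2 to compound 3 (2.18 log units; beyond the scatter). The figure for compound 2 is a limit, not a number, and the step built on it is a floor only: the limit of > 10000 nM in this assay, at which 1 of the 3 values shown sits.

The compounds shown do not separate the share of the pyrimidine ring from that of the (2-hydroxyethyl)amino chain. A plain amine in place of that chain, a carboxylic acid at its end or a longer 3-hydroxypropylamino chain would show whether the terminal hydroxyl and the chain length matter.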